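The compounds below may be only part of what the source reports. "The series", "measured", "known", "first", "only" and "open" are said of these compounds alone.

Compound 1 `Cc1cc([C@@H]2C[C@H]2C(=O)O)ccc1-c1noc(-c2ccc(OC(C)C)c(C(F)(F)F)c2)n1` gives > 10000 nM in an assay on CHO cells for displacement of a labelled ligand from sphingosine 1-phosphate receptor 2 (Homo sapiens) (on this read-out higher numbers stand for weaker inhibition and lower numbers for stronger inhibition), which is a limit of the assay and not a number.
Compound 2 `Cc1cc([C@H]2C[C@H]2C(=O)O)ccc1-c1noc(-c2ccc(OC(C)C)c(C#N)c2)n1` gives > 10000 nM in this assay, again a limit.
Compound 3 `Cc1cc([C@@H]2C[C@H]2C(=O)O)ccc1-c1noc(-c2ccc(OC(C)C)c(C#N)c2)n1` gives > 10000 nM; > 10000 nM; > 10000 nM (3 entries) in this assay, every one of its entries a limit.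

Compound 1 therefore stands nowhere in particular on the numbers shown: it sits at the ceiling of the measurement, as do the other two compounds, so that no compound among the three can be ranked against another. The picture is uniform, as the limit of > 10000 nM in this assay, at which 2 of the 3 values shown sit, makes plain, and it is not moved by stereochemistry either, since the fact that compounds 2 and 3 differ only in the configuration as drawn and both of those compounds sit at the same limit.

Compound 4 `Cc1cc(CCC(=O)O)ccc1-c1noc(-c2ccc(OC(C)C)c(C(F)(F)F)c2)n1` is the one not yet measured. Relative to compound 1 the change is 2-carboxyethyl in place of 2-carboxycyclopropyl on an aromatic carbon, in words a 2-carboxyethyl in place of 2-carboxycyclopropyl on an aromatic carbon. For the measured compounds named here, no step between measured compounds is available to size this change, and nothing among the measured compounds gives a value that the step could start from. The expectation for compound 4 is accordingly no shift beyond the scatter, that is a step that the limit leaves unreadable from compound 1 to compound 4, with the assay most likely reporting a limit once more. Compound 4 is estimated at 20000 nM, within 5000 nM to 100000 nM.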

Compound 4, half-maximal inhibitory concentration: > 10000 nM
Compound 4 was reported as a limit (the forecaster's own chance of this, stated with the estimate: 85%); the middle value does not contradict the limit.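

In this assay compound 4 gives > 10000 nM, a limit of the assay and not a number. For the compounds shown here, compound 1 also stands at a limit, so no step from compound 1 to compound 4 can be read. The compounds shown leave open whether 2-carboxyethyl or 2-carboxycyclopropyl makes any difference in this assay, since none of them gives a value within its range.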